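The compounds below may be only part of what the source reports. "The series", "measured", "known", "first", "only" and "open" are said of these compounds alone.

Working notes on the series in a functional assay on the whole organism for inhibition, with Mus musculus as the target, in the writhing test, with stated times of 30 min and 2 h, at a dose of 25 mg/kg by the intraperitoneal route; on this read-out higher numbers stand for more inhibition at the one dose given (going by the name of the read-out) and lower numbers for less inhibition.

Three compounds have been run. Compound 1 `C=C(C)C(=O)c1ccc(OC)cc1OC` gives 20% in this assay. Compound 2 `CCOC(=O)c1nn(-c2ccc(Cl)cc2)c(-c2ccc(OC)cc2OC)c1C` gives 40% in this assay. Compound 3 `COc1ccc(C2=NN(C(=O)NS(=O)(=O)c3ccc(C)cc3)CC2C)c(OC)c1` gives 20% in this assay. On these numbers compound 2 stands highest of the three; compound 1 and compound 3 each sit below it by more than the usual scatter, and compound 1 and compound 3 are within the scatter of each other. The three compounds differ in more than one place, so no single structural change can be read off against any of these gaps.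

Compound 4 `COc1ccc(-c2c(C)c(C(=O)O)nn2-c2ccc(Cl)cc2)c(OC)c1` is not yet measured. It differs from compound 2 in one place: hydrogen in place of ethyl on an oxygen next to a carbonyl group. For the measured compounds named here, no measured pair in this set is separated by this change alone, so nothing here shows the size of the step directly; the value of compound 2 is the only anchor.

The step from compound 2 to compound 4 is expected to be small, a number 8 percentage points lower from compound 2 to compound 4 (within the scatter), most likely no change beyond the scatter or a modest fall. Compound 4 is therefore estimated at 32% in this assay, with a likely range from 12% to 52%.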

Compound 4, a percentage reported as inhibition, in the whole organism at one dose (the size of the read-out at that dose, not a potency): 20%
Beside the measured number, compound 4's estimate is 12 percentage points above it, and the stated range covers the measured number.
By their numbers in this assay, from the lowest: compounds 1, 3 and 4 (each within the scatter of the next); then compound 2.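

For the compounds shown here, the first single-place pair shows that this position is not indifferent to the change from ethoxycarbonyl to carboxy: in this assay, hydrogen in place of ethyl on an oxygen next to a carbonyl group gives a number 20 percentage points lower from compound 2 to compound 4 (beyond the scatter). The earlier compounds shown here differ in more than one place and could not isolate any such step, whereas here compound 2 at 40% and compound 4 at 20% share everything except this one group. The ethyl therefore counts for something at this one dose, although this single pair gives only the size of the read-out at that dose, not a potency, and nothing at hand bears on the reason for the step.

The compounds shown leave open how the read-out responds to other groups on this oxygen, such as methyl or a longer chain like butyl. They also leave open whether an amide, with an amine in place of the ethoxy, would stay with compound 2 or with compound 4 in this read-out.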